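Alkoxy variation on a triazine-type agonist series

The source may hold more compounds than are shown below. What is called first, only, known or untested is meant among the compounds shown, and "the series" means these compounds.

Measured so far: compound 1 `CCCCNc1nc(N)nnc1OC` with 2040 nM; compound 2 `CCCCNc1nc(N)nnc1OCCOC` with 1000 nM.

In an assay on isolated protein for agonist activity at Toll-like receptor 8 (Homo sapiens) (a higher number here means that more compound is needed for the effect, a lower number that less compound is needed), compound 2 stands lowest of the two numbers; the nearest is compound 1, whose value is 2040 nM. Compound 3 `CCCCNc1nc(N)nnc1OC(C)C` differs from compound 2 by isopropyl in place of 2-methoxyethyl on an oxygen on an aromatic ring. Among the compounds with values here, the only measured step, a 2.0-fold lower number from compound 1 to compound 2 (0.31 log units; beyond the scatter), concerns a chain extended by methoxymethyl, not a branched chain without the acceptor, so it bears on this change only loosely. No step beyond the scatter is therefore expected. Compound 3 is estimated at 1500 nM, with a range of 600 nM to 4000 nM. That estimate means an expected step of a 1.5-fold higher number from compound 2 to compound 3 (0.18 log units; within the scatter).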

Compound 3, half-maximal effective concentration: 460 nM
The estimate for compound 3 lay 3.3-fold (0.51 log units) above the measured number; measured number outside the range, below it.
By their numbers in this assay, from the lowest: compound 3; then compound 2; then compound 1.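

In this assay, the oxygen on the aromatic ring does not need a hydrogen-bond acceptor in its chain for a lower number: isopropyl in place of 2-methoxyethyl gives a further drop (a 2.2-fold lower number from compound 2 to compound 3 (0.34 log units; beyond the scatter)). Isopropyl in place of methyl gives the largest step so far (a 4.4-fold lower number from compound 1 to compound 3 (0.65 log units; beyond the scatter)), so compound 3 now stands lowest of the three. Nothing at hand explains this order.

Still open, going by these compounds, is whether branching itself matters, since an unbranched propyl chain would separate it from chain size. A cyclopentyl ring or a terminal amine on this oxygen also remains to be placed in the order.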